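The source may hold more compounds than are shown below. What is called first, only, known or untested is meant among the compounds shown, and "the series" means these compounds.

Measured in a functional assay on UACC-62 cells (Homo sapiens) for inhibition, read by sulforhodamine B assay, with a stated time of 24 h; a lower number here means a stronger inhibitor, a higher number a weaker inhibitor:
- compound 1 `Cc1ccc(C(=O)/C=C/c2ccc(C(=O)O)cc2)o1` gives 58000 nM
- compound 2 `O=C(O)c1ccc(/C=C/C(=O)c2ccccc2)cc1` gives 13900 nM
- compound 3 `COc1ccc(C(=O)/C=C/c2ccc(C(=O)O)cc2)cc1[N+](=O)[O-]` gives 13400 nM

Compound 3 cannot be told apart from compound 2, and both numbers lie clearly under that of compound 1. Compound 4 `COc1ccc(C(=O)/C=C/c2ccc(C(=O)O)cc2)cc1OC` has methoxy in place of nitro on an aromatic carbon, ortho to a methoxy group (methoxy in place of nitro on an aromatic carbon). Going by the values given here, the only measured step, a 4.2-fold lower number from compound 1 to compound 2 (0.62 log units; beyond the scatter), is a different change, phenyl in place of 5-methylfuran-2-yl on a carbonyl carbon, so it says nothing direct about this swap. Compound 2, with neither nitro nor methoxy, gives 13900 nM and compound 3 gives 13400 nM, so no step beyond the scatter is expected in this assay. The estimated change is a 1.1-fold higher number from compound 3 to compound 4 (0.05 log units; within the scatter) and is expected to stay within the scatter. For compound 4 the estimated value is 15000 nM with an expected range from 6000 nM to 35000 nM.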

Compound 4, half-maximal inhibitory concentration: 7870 nM
Compound 4: the middle estimate sits 1.9-fold (0.28 log units) above what was measured; the range from low to high includes it.
By their numbers in this assay, from the lowest: compounds 4, 3 and 2 (each within the scatter of the next); then compound 1.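

In this assay, going by these compounds alone, putting methoxy in place of nitro on this aromatic carbon, ortho to a methoxy group, gives a 1.7-fold lower number from compound 3 to compound 4 (0.23 log units; within the scatter) and so provides the first direct reading of this swap. Compound 3 and compound 4 cannot be told apart, even though the two groups differ in their heavy atoms and hydrogen-bond acceptors. No measured evidence explains this result. Going by these compounds, whether an amine or a chlorine atom at this position would also match these compounds remains open. So does whether the swap would give the same result with a 5-methylfuran-2-yl group on the carbonyl carbon.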